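Moving the halogen on the anilide ring

The source may report more compounds than this note shows. Statements on the series, on what has been measured and on what is new or still open speak of the compounds shown alone.

Measured so far in a functional assay on A549 cells (Homo sapiens) for inhibition, read by CCK-8 assay, with a stated time of 72 h, tested at 1 uM; a lower number here means less inhibition of growth, a higher number more inhibition of growth at the concentration tested:
- compound 1 `CN(C)C(=O)c1cc2cnc(Nc3ccc(NC(=O)C4(C(=O)Nc5cccc(F)c5)CC4)cc3)nc2n1C1CCCC1`: 33.2%
- compound 2 `CN(C)C(=O)c1cc2cnc(Nc3ccc(NC(=O)C4(C(=O)Nc5cccc(Cl)c5)CC4)cc3)nc2n1C1CCCC1`: 8.3%

Of these two, compound 2 has the lower number, at 8.3% in this assay. The next compound, compound 3 `CN(C)C(=O)c1cc2cnc(Nc3ccc(NC(=O)C4(C(=O)Nc5ccc(Br)cc5)CC4)cc3)nc2n1C1CCCC1`, differs from it as follows: 4-bromophenyl in place of 3-chlorophenyl on an amide-type nitrogen. In words, 4-bromophenyl stands in place of 3-chlorophenyl on an amide-type nitrogen.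

Within the data shown here, only one measured step bears on this change: a number 24.9 percentage points lower from compound 1 to compound 2 (beyond the scatter). There, chloro replaced fluoro on an aromatic carbon, and the drop was modest but beyond the usual scatter. That step shows that a small swap on this ring can matter. Among the measured compounds shown here, no measured step shows what a new ring position does, so the direction is uncertain. With compound 2 already low, a small rise seems more likely than a further fall.

The expected change is a number 6.7 percentage points higher from compound 2 to compound 3 (within the scatter). For compound 3 the estimated value is 15%, with an expected range of 2% to 38%.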

Compound 3, percent growth inhibition at one concentration: -6.6%
Beside the measured number, compound 3's estimate is 21.6 percentage points above it; the whole stated range lies above it.
By their numbers in this assay, from the lowest: compound 3; then compound 2; then compound 1.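

In this assay, replacing 3-chlorophenyl with 4-bromophenyl on the amide-type nitrogen gives a number 14.9 percentage points lower from compound 2 to compound 3 (beyond the scatter), so a compound that already read low could still fall, here to below zero. Among these compounds, measured against the 3-fluorophenyl group, the same 4-bromophenyl group gives a number 39.8 percentage points lower from compound 1 to compound 3 (beyond the scatter), the largest step so far and one that makes compound 3 the least active of the three. Nothing shown explains either fall.

Because the halogen and its place on the ring change together in this step, the compounds shown cannot say which of the two matters, and a 3-bromophenyl or 4-chlorophenyl group would separate them. Also open, going by these compounds, is how a plain phenyl ring, or one carrying an amine or a methoxy group, would read here.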